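The compounds below may be only part of what the source reports. "The series", "measured", "known", "first", "only" and "open" are said of these compounds alone.

Working notes on the series.

All compounds share the core seen in compound 1 `CON1C[C@@H](NC(=O)OCCCCC2CCCCC2)C1=O` and carry the same carbamate chain; they differ at the substituent on the ring nitrogen and at the ring carbon bearing a methyl. In an assay on HEK293 cells for inhibition of N-acylethanolamine-hydrolyzing acid amidase (Homo sapiens), read by fluorescence, with stated times of 10 min and 50 min (a higher number here means a weaker inhibitor, a lower number a stronger inhibitor), compound 1 gives 56 nM. Compound 2 `CCCCCON1C(=O)[C@@H](NC(=O)OCCCCC2CCCCC2)[C@@H]1C`, with a pentyloxy group on the ring nitrogen and the added ring methyl, gives 387 nM in this assay. Among the compounds with values here, compound 3 `CCCCCCCON1C(=O)[C@@H](NC(=O)OCCCCC2CCCCC2)[C@@H]1C` gives 2230 nM in this assay, the highest number of the three; the single step that reaches it, a 5.8-fold higher number from compound 2 to compound 3 (0.76 log units; beyond the scatter), lies beyond the scatter, and the gap to compound 1 is wider still.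

Compound 4 `C[C@H]1[C@H](NC(=O)OCCCCC2CCCCC2)C(=O)N1OCCCS(C)(=O)=O` is the next member. The change from compound 3 is methylsulfonyl in place of butyl on a saturated chain carbon, three bonds along the chain from an oxygen on an unsaturated carbon. Within the data shown here, no measured step covers an exchange of chain carbon for methylsulfonyl; the only step on this chain is the lengthening from compound 2 to compound 3, which raised the number. Since compound 4 cuts the carbon chain back toward the length of compound 2 while adding a group without precedent here, the expectation is a lower number than compound 3, near compound 2, with wide uncertainty: the estimated step is a 3.2-fold lower number from compound 3 to compound 4 (0.50 log units; beyond the scatter). Compound 4 is thus expected at 700 nM, between 150 nM and 3000 nM.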

Compound 4, half-maximal inhibitory concentration: 49 nM
Compound 4: the middle estimate sits 14-fold (1.15 log units) above what was measured; the whole stated range lies above it.
By their numbers in this assay, from the lowest: compounds 4 and 1 (each within the scatter of the next); then compound 2; then compound 3.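

In this assay the exchange of butyl for methylsulfonyl, on a saturated chain carbon three bonds along the chain from an oxygen on an unsaturated carbon, brings a 46-fold lower number from compound 3 to compound 4 (1.66 log units; beyond the scatter) at a constant count of 4 heavy atoms in the group, so chain size alone does not set the number at this position. Against the shorter chain, methylsulfonyl in place of ethyl still brings a 7.9-fold lower number from compound 2 to compound 4 (0.90 log units; beyond the scatter) in the same direction, which means the gain is not only the undoing of the earlier rise of a 5.8-fold higher number from compound 2 to compound 3 (0.76 log units; beyond the scatter) on lengthening. The two new steps therefore show that this chain end responds strongly to what the group is made of, here a group with sulfur and 2 hydrogen-bond acceptors in place of an all-carbon end.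

Nothing at hand bears on the reason for this drop. Still open, as far as these compounds go, is whether a nitrile, a sulfonamide or a carboxylic acid at the same chain end would give a similar number, and whether 2-(methylsulfonyl)ethyl or a longer chain carrying methylsulfonyl would keep it.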